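The source may hold more compounds than are shown below. What is called first, only, known or untested is meant among the compounds shown, and "the series" means these compounds.

Within the data shown here, compound 2 `CCc1cccc2c(OC)c(-c3occ(C)c3COC)ccc12` is one of two compounds measured in a functional assay on ZR-75-1 cells (Homo sapiens) for cytotoxicity, read by MTT assay, with a stated time of 72 h; on this read-out lower numbers stand for an effect already at smaller amounts and higher numbers for an effect only at larger amounts of compound. In this assay compound 2 gives 9.7 ug/mL, the higher of the two numbers. The other is compound 1 `CCc1cccc2c(OC)c(-c3occ(C)c3C(=O)OC)ccc12`, which in this assay gives 1.3 ug/mL. Among the measured compounds shown here, the only measured step is a 7.5-fold higher number from compound 1 to compound 2 (0.87 log units; beyond the scatter), and it exchanges a methoxycarbonyl for a methoxymethyl on an aromatic carbon; it does not touch the chain carbon that changes in the next compound.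

Compound 3 `CCOCc1c(C)coc1-c1ccc2c(CC)cccc2c1OC` differs from compound 2 by methyl in place of hydrogen on a saturated chain carbon bound to an oxygen on a saturated carbon. For the measured compounds named here, no measured step bears on this change, so there is nothing in the data to point in either direction. The step from compound 2 to compound 3 is therefore expected to stay within the scatter, which is what a 1.0-fold higher number from compound 2 to compound 3 (0.01 log units; within the scatter) expresses. On that basis compound 3 is estimated to give about 10 ug/mL in this assay, with a range from 4 ug/mL to 25 ug/mL.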

Compound 3, concentration for half-maximal effect: 9.1 ug/mL
Compound 3: the middle estimate sits 1.1-fold (0.04 log units) above what was measured, within the range that was stated.
By their numbers in this assay, from the lowest: compound 1; then compounds 3 and 2 (each within the scatter of the next).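

In this assay the change from methoxymethyl to ethoxymethyl, methyl in place of hydrogen on a saturated chain carbon bound to an oxygen on a saturated carbon, is a 1.1-fold lower number from compound 2 to compound 3 (0.03 log units; within the scatter) and so does not separate the two compounds. The earlier compounds shown here showed only that methoxymethyl differs from methoxycarbonyl; the new compound shows that this gap is not tied to methoxymethyl alone, for the exchange of methoxycarbonyl for ethoxymethyl is a 7.0-fold higher number from compound 1 to compound 3 (0.85 log units; beyond the scatter) and is close in size to a 7.5-fold higher number from compound 1 to compound 2 (0.87 log units; beyond the scatter) on the same core. Among these three compounds, then, the number follows the methoxycarbonyl group and not the length of the end of the chain, and no measurement offered here gives a reason for either finding.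

From the compounds shown here alone, it remains open whether a longer chain such as propoxymethyl, or a hydroxymethyl or aminomethyl group at this place, would also leave the number where compound 2 and compound 3 stand. Equally open, going by these compounds, is whether the lower number of compound 1 would hold for an ethoxycarbonyl group, a carboxylic acid or an amide in place of methoxycarbonyl.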